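A few compounds are considered here, and "the series" means these few. Any claim that something is new, unique, unknown or untested is made for them only; others in the source may bear on it.

In a functional assay on HepG2 cells (Homo sapiens) for inhibition, read by MTT assay, with a stated time of 48 h (on this read-out lower numbers stand for stronger inhibition and higher numbers for weaker inhibition), compound 1 (`COc1cc(-c2nnc(SCc3ccccc3)n2-c2ccc(N(C)C)cc2)cc(OC)c1OC`) gives > 60000 nM as a limit of the assay and not a number. Compound 2 (`COc1cc(-c2nnc(SCC(=O)c3ccc4ccccc4c3)n2-c2ccc(N(C)C)cc2)cc(OC)c1OC`) gives > 60000 nM which is likewise a limit. Compound 3 (`COc1cc(-c2nnc(SCC(=O)C3CC3)n2-c2ccc(N(C)C)cc2)cc(OC)c1OC`) gives > 60000 nM which is also a limit, so it has no number that would place it in the series.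

Compound 4 (`CCOC(=O)CSc1nnc(-c2cc(OC)c(OC)c(OC)c2)n1-c1ccc(N(C)C)cc1`) has ethoxy in place of cyclopropyl on a carbonyl carbon and the same difference reads cyclopropylcarbonyl to ethoxycarbonyl.

Among the measured compounds shown here, three measured steps bear on this change, and none has a readable size: a step that the two limits leave unreadable from compound 1 to compound 3 then a step that the two limits leave unreadable from compound 2 to compound 3 and finally a step that the two limits leave unreadable from compound 1 to compound 2 as the remaining pair. For the measured compounds named here, the only guide in this assay is the limit of > 60000 nM in this assay, at which 3 of the 3 values shown sit, and this gives no direction. The expected change is a number no higher from compound 3 to compound 4 (the limit leaves the size open) and no step beyond the scatter is expected in either direction.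

Compound 4 is estimated at 60000 nM with an expected range from 30000 nM to 120000 nM and will probably be reported only as a limit.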

Compound 4, half-maximal inhibitory concentration: > 60000 nM
Compound 4 ended at the assay's limit; the forecaster's own chance of this, stated with the estimate: 85%; the middle value sits exactly at the limit.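

In this assay, among the compounds shown here, compound 4 gives > 60000 nM as a limit of the assay and not a number, so no new step linking it to compound 1, compound 2 or compound 3 can be read. Whether these side chains differ at all stays open, because no compound shown has a readable number: the limit of > 60000 nM in this assay, at which 4 of the 4 values shown sit.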